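Adding a Chloro Group to Compound 2

A few compounds are considered here, and "the series" means these few. Any claim that something is new, unique, unknown or untested is made for them only; others in the source may bear on it.

Compound 1 `COc1ccc(S(=O)(=O)c2ccc3cccc(/C=C/C(=O)NO)c3n2)cc1` and compound 2 `O=C(/C=C/c1cccc(S(=O)(=O)c2ccc3ccccc3n2)c1)NO` have both been measured in a functional assay on PC-3 cells (Homo sapiens) for antiproliferative activity, read by sulforhodamine B assay, with a stated time of 48 h; a lower number here means a stronger inhibitor of growth, a higher number a weaker inhibitor of growth. There, compound 1 gives 790 nM and compound 2 gives 150 nM. Compound 2 therefore holds the lower of the two numbers, and the gap between them lies beyond the usual scatter of repeated measurements. The two structures differ in more than one place, so this gap cannot be tied to any single feature. Compound 3 `O=C(/C=C/c1cccc(S(=O)(=O)c2ccc3cc(Cl)ccc3n2)c1)NO` has not yet been measured. It is compound 2 with one change: chloro in place of hydrogen on an aromatic carbon. Within the data shown here, no measured pair here shows what a single change of this kind does, so the expectation is a cautious one. In this assay, the change is expected to produce no step beyond the scatter, with a slight lean toward stronger growth inhibition. The estimated step is a 1.3-fold lower number from compound 2 to compound 3 (0.10 log units; within the scatter). For compound 3, the expected value is 120 nM, with an estimated range from 45 nM to 320 nM.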

Compound 3, concentration for 50% growth inhibition: 760 nM
Compound 3: middle estimate off by 6.3-fold (0.80 log units), on the low side, outside the stated range (above it).
By their numbers in this assay, from the lowest: compound 2; then compounds 3 and 1 (each within the scatter of the next).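

Among these compounds, this is the first pair in the set that differs in one place only, so a single change can now be read on its own: in this assay, putting chloro in place of hydrogen on this aromatic carbon, meta to a fused ring and para to a fused ring, gives a 5.1-fold higher number from compound 2 to compound 3 (0.70 log units; beyond the scatter). At this position, then, the hydrogen cannot be exchanged for chloro without a real weakening of growth inhibition, even though the change adds just one heavy atom, with no ring, no hydrogen-bond donor and no hydrogen-bond acceptor. No supporting measurement bears on why the number rises, so the result stands as an observation without an explanation.

From the compounds shown here alone, with one group on one carbon, it remains open whether a fluoro, a methyl or an amine on the same carbon would weaken growth inhibition to a similar degree, or whether chloro on a different carbon would do the same. Going by these compounds, it also remains open whether chloro at the matching place on the core of compound 1 would produce a step of similar size.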